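The source may report more compounds than this note shows. Statements on the series, on what has been measured and on what is new or still open speak of the compounds shown alone.

In a functional assay on M14 cells (Homo sapiens) for antiproliferative activity, with a stated time of 72 h; on this read-out higher numbers stand for weaker inhibition and lower numbers for stronger inhibition:
- compound 1 `C=CC[C@H]1C[C@]2([C@@H](C)Cc3ccc(OC)cc3)OCOC2=CC1=O`: 20 nM
- compound 2 `C=CC[C@H]1C[C@]2([C@@H](C)Cc3ccc(OC)nc3)OCOC2=CC1=O`: 180 nM
- compound 3 `C=CC[C@H]1C[C@]2([C@@H](C)Cc3ccc(OC)cc3F)OCOC2=CC1=O`: not yet measured

Of the two measured compounds, compound 1 has the lower number, at 20 nM, and so shows the stronger inhibition. Compound 3 differs from compound 1 by fluoro in place of hydrogen on an aromatic carbon, ortho to a large group and meta to a methoxy group.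

Among the compounds with values here, no measured step covers this change directly. The nearest is a 9.0-fold higher number from compound 1 to compound 2 (0.95 log units; beyond the scatter), where 6-methoxypyridin-3-yl replaces 4-methoxyphenyl. That step alters the same aromatic unit and shows that a change there can move the number in this assay beyond the scatter. However, it replaces part of the ring itself, whereas compound 3 keeps the ring and adds one fluoro. Its size is therefore taken only as a rough upper guide, and a smaller step is expected, probably towards a higher number and possibly within the scatter.

The expected step is a 1.5-fold higher number from compound 1 to compound 3 (0.18 log units; within the scatter). For compound 3 the estimated value is 30 nM, with an expected range of 10 nM to 100 nM.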

Compound 3, half-maximal inhibitory concentration: 14 nM
For compound 3 the middle estimate is 2.1-fold (0.33 log units) above the measured one, within the range that was stated.
By their numbers in this assay, from the lowest: compounds 3 and 1 (each within the scatter of the next); then compound 2.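

Working notes on the aromatic ring: in this assay, fluoro in place of hydrogen on an aromatic carbon, ortho to a large group and meta to a methoxy group, gives a 1.4-fold lower number from compound 1 to compound 3 (0.15 log units; within the scatter) and so leaves compounds 1 and 3 indistinguishable on this read-out. Within the data shown here, this is the first sign that the six-membered aromatic ring of carbon only accepts an added fluorine at this carbon without a change beyond the scatter. The earlier step, a 9.0-fold higher number from compound 1 to compound 2 (0.95 log units; beyond the scatter), showed only that replacing 4-methoxyphenyl with 6-methoxypyridin-3-yl moves the number beyond the scatter, so the aromatic unit is not sensitive to every edit. No measurement available here explains why the fluoro is tolerated and this note therefore records the outcome only.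

The compounds shown leave open whether chloro, methyl or an amine on this same aromatic carbon would also stay within the scatter of compound 1, and whether fluoro on the other aromatic carbons would do so. Also open, on these data alone, is how an ethoxy group or a hydroxy group in place of the methoxy group would read alongside this fluoro.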